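Dichlorophenyl for dimethoxyphenyl on a shared core

The source may hold more compounds than are shown below. What is called first, only, known or untested is meant among the compounds shown, and "the series" means these compounds.

Measured compounds:
Compound 1, `Cc1n[nH]c2ccc(-c3nc4cnc(N5CCN(C)CC5)cn4c3Nc3cccc(Cl)c3)cc12`: in a functional assay on CWR22R cells (Homo sapiens) for inhibition, with a stated time of 120 h, tested at 10 uM (on this read-out lower numbers stand for less inhibition and higher numbers for more inhibition at the one concentration tested (going by the name of the read-out)), compound 1 gives "not determined" (no result reported), that is, no result reported.
Compound 2, `COc1ccc(Nc2c(-c3ccc4[nH]nc(C)c4c3)nc3cnc(N4CCN(C)CC4)cn23)cc1OC`: in this assay compound 2 gives 0%.

Among the measured compounds shown here, compound 2 thus stands as the only compound with a number in this assay, and that number shows no inhibition at the single concentration tested; compound 1 carries no result at all, so no step between measured compounds can be stated.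

Compound 3, `Cc1n[nH]c2ccc(-c3nc4cnc(N5CCN(C)CC5)cn4c3Nc3cc(Cl)ccc3Cl)cc12`, differs from compound 2 in one place: 2,5-dichlorophenyl in place of 3,4-dimethoxyphenyl on a nitrogen on an aromatic ring

For the measured compounds named here, with no measured step to lean on, the expectation for this change rests only on compound 2 and its value of 0%. Because compound 2 gives 0%, a downward move cannot be observed, so the expected step from compound 2 to compound 3 is estimated at a number 10 percentage points higher from compound 2 to compound 3 (within the scatter), a small rise that may well stay within scatter. Compound 3 is therefore expected to give about 10%, with a range from 0% to 40%.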

Compound 3, a percentage reported as inhibition, at one concentration (the size of the read-out at that concentration, not a potency): 3.8%
Beside the measured number, compound 3's estimate is 6.2 percentage points above it, within the range that was stated.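

In this assay, among the compounds shown here, putting 2,5-dichlorophenyl in place of 3,4-dimethoxyphenyl on a nitrogen on an aromatic ring gives a number 3.8 percentage points higher from compound 2 to compound 3 (within the scatter), the first step that can be read at this position. Two aryl groups with different substituents, methoxy in one and chlorine in the other, therefore cannot be told apart here, and both compounds stay close to the bottom of the read-out at the one concentration tested. No measurement at hand bears on why this exchange leaves the read-out within the scatter.

Still open, going by these compounds, is whether any group on this nitrogen can give inhibition beyond the scatter, for example a phenyl ring bearing a carboxylic acid or an amine on a longer chain. Compound 1 gives "not determined" (no result reported), so any step involving it cannot be read.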